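Working notes: side-chain variation, compound 2 to compound 3

The compounds below may be only part of what the source reports. "The series", "measured", "known", "first", "only" and "open" are said of these compounds alone.

Measured so far:
compound 1 `CCCn1c(=O)n(CCOC)c(=O)c2[nH]cnc21` — in an assay on Cerebral cortex for binding affinity to adenosine receptor A1 (Cavia porcellus), read by radioligand binding (on this read-out lower numbers stand for stronger inhibition and higher numbers for weaker inhibition), compound 1 gives 2500 nM
compound 2 `CCCn1c(=O)n(CCCOC)c(=O)c2[nH]cnc21` — in this assay compound 2 gives 12400 nM

Compound 2 stands at the highest of the two numbers in hand; its nearest neighbour is compound 1, and the step between them reads a 5.0-fold higher number from compound 1 to compound 2 (0.70 log units; beyond the scatter). Compound 3 `CCCn1c(=O)n(CCC(C)=O)c(=O)c2[nH]cnc21` differs from compound 2 by acetyl in place of methoxymethyl on a saturated chain carbon, two bonds along the chain from an aromatic nitrogen. For the measured compounds named here, the single measured step concerns methoxymethyl replacing methoxy, not acetyl replacing methoxymethyl, so it bears on the present change only loosely. With no measured exchange of this kind, nothing argues for a shift beyond the scatter in either direction, though a return toward the range of compound 1 cannot be ruled out. The expected step is a 1.6-fold lower number from compound 2 to compound 3 (0.19 log units; within the scatter). For compound 3 the estimate in this assay is 8000 nM, within a range of 2000 nM to 30000 nM.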

Compound 3, inhibition constant: 11200 nM
Compound 3: middle estimate off by 1.4-fold (0.15 log units), on the low side; low and high end bracket the measured number.
By their numbers in this assay, from the lowest: compound 1; then compounds 3 and 2 (each within the scatter of the next).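

In this assay the exchange of methoxymethyl for acetyl on a saturated chain carbon, two bonds along the chain from an aromatic nitrogen, gives a 1.1-fold lower number from compound 2 to compound 3 (0.04 log units; within the scatter) and so leaves the read-out within the scatter: at this position the two groups cannot be told apart, despite the double bond that acetyl brings. Compound 1 stays apart from both, with a 4.5-fold higher number from compound 1 to compound 3 (0.65 log units; beyond the scatter) alongside a 5.0-fold higher number from compound 1 to compound 2 (0.70 log units; beyond the scatter) as the two steps beyond the scatter, so among these three compounds only the methoxy compound gives the distinctly lower number. Nothing at hand explains why the acetyl and methoxymethyl compounds read alike.

On these data alone, whether a hydroxyl, an amine or a carboxylic acid at this position would fall near compound 1 or near the other two remains open. So does the effect of a longer chain carrying the acetyl group.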